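This account rests on a few compounds, and the source may have more. Where it says the series, first, only, none or still open, it means among the compounds named here.

Working notes on the series. The shared core carries an amide and a benzyl group on a thiazole-type unit; compound 1 `O=C(Nc1ncc(Cc2cccc(C(F)(F)F)c2)s1)c1ccc2ccccc2c1` is the naphthamide with a trifluoromethyl on the benzyl ring. In an assay on microsomes for inhibition of acyl-CoA desaturase 1 (Mus musculus), with a stated time of 60 min (on this read-out lower numbers stand for stronger inhibition and higher numbers for weaker inhibition), compound 1 gives > 10000 nM, which is a limit of the assay and not a number (the limit of > 10000 nM in this assay, at which 1 of the 3 values shown sits). Compound 2 `COc1ccc(C(=O)Nc2ncc(Cc3cccc(C(F)(F)F)c3)s2)cc1` keeps the trifluoromethyl and swaps the naphthamide for a methoxy-bearing benzamide; in this assay compound 2 gives "not determined" (no result reported), so no result is available. Among the compounds with values here, compound 3 `COc1ccc(C(=O)Nc2ncc(Cc3cccc(F)c3)s2)cc1OCCO` adds a hydroxyethoxy group to the benzamide and carries fluoro on the benzyl ring; in this assay compound 3 gives 2 nM, the only numeric value in hand among the three compounds.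

Compound 4 `COc1ccc(C(=O)Nc2ncc(Cc3cccc(C(C)(C)C)c3)s2)cc1OCCO` is not yet measured. It differs from compound 3 only by tert-butyl in place of fluoro on an aromatic carbon. Within the data shown here, no measured pair bears on this exchange, so no step size can be read from the data. The expectation is a modest loss, with the step from compound 3 to compound 4 estimated as a 7.5-fold higher number from compound 3 to compound 4 (0.88 log units; beyond the scatter). Compound 4 is therefore expected to give about 15 nM in this assay, within a range of 2 nM to 150 nM.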

Compound 4, half-maximal inhibitory concentration: 1310 nM
For compound 4 the middle estimate is 87-fold (1.94 log units) below the measured one; the whole stated range lies below it.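

In this assay, within the data shown here, the exchange of fluoro for tert-butyl, on an aromatic carbon meta to a large group, gives a 660-fold higher number from compound 3 to compound 4 (2.82 log units; beyond the scatter) as the first step that can be read at all. The benzyl substituent at this position therefore matters strongly for this read-out when the hydroxyethoxy benzamide is held fixed, which compounds 1 and 2 could not show, since they differ from the others in more than one place and offer no numeric value for comparison. Nothing measured in the series bears on the cause of this step.

Going by these compounds, with only fluoro and tert-butyl compared directly at this position, it remains open whether the number climbs gradually with the heavy-atom count of the group or changes abruptly somewhere between them, and methyl, chloro or isopropyl on the same carbon would separate these cases. On these data alone, it is also open whether the exchange carries the same cost with a different amide portion, such as one bearing an amine or a carboxylic acid in place of the hydroxyethoxy chain.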